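This account rests on a few compounds, and the source may have more. Where it says the series, first, only, none or still open, it means among the compounds named here.

Compound 3, `CCCCCCCCOP(=O)(O)OCCSC(=S)N1CCCCCC1`, was measured in an ADME assay on HEK293 cells (Homo sapiens) for inhibition, read by MTT assay, with stated times of 18 h and 4 h; on this read-out higher numbers stand for weaker inhibition and lower numbers for stronger inhibition. In this assay compound 3 gives only a limit of the assay, > 100000 nM, and not a number. The other two compounds measured stand at the same limit. Compound 1, `CCCCCCCCCCCCCCCCOP(=O)(O)OCCSC(=S)N1CCCCC1`, gives in this assay a limit of > 100000 nM. Compound 2, `CCCOP(=O)(O)OCCSC(=S)N1CCCC1`, gives in this assay a limit of > 100000 nM. For the measured compounds named here, compound 3 therefore stands where every measured value stands, at the limit of > 100000 nM in this assay, at which 3 of the 3 values shown sit, and no step between any two measured compounds can be sized. Compound 4, `CCCOP(=O)(O)OCCSC(=S)N1CCCCCC1`, is not yet measured; it differs from compound 3 by hydrogen in place of pentyl on a saturated chain carbon, three bonds along the chain from an oxygen on an unsaturated carbon. Compound 2 carries the same propyl chain as compound 4 and sits at the limit in this assay. The step from compound 3 to compound 4 is expected to be a step that the limit leaves unreadable from compound 3 to compound 4, none beyond the scatter. Compound 4 is expected to give 200000 nM in this assay, most likely again only a limit, within a range from 100000 nM to 1000000 nM.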

Compound 4, half-maximal inhibitory concentration: 54000 nM
Compound 4: middle estimate off by 3.7-fold (0.57 log units), on the high side, and the stated range ends above it.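

In this assay compound 4 is the first compound shown to give a number and not a limit, so hydrogen in place of pentyl on this saturated chain carbon, which also reads as octyl to propyl, is the first change shown to reach a readable value. Compound 3 gives > 100000 nM here, which is only a limit. The change therefore reads only as a floor (an at least 1.8-fold lower number from compound 3 to compound 4 (0.26 log units; that floor lies within the scatter)), its full size stays unknown, and every other step among the compounds shown cannot be read: the limit of > 100000 nM in this assay, at which 3 of the 4 values shown sit.

The compounds shown leave open how the number behaves with butyl or pentyl in place of the propyl chain on the core of compound 4. They also leave open what an amine or a carboxylic acid in that place would give.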